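A few compounds are considered here, and "the series" means these few. Any claim that something is new, unique, unknown or untested is made for them only; others in the source may bear on it.

Compound 1 `O=C1O/C(=C\Cn2cc(-c3ccc(Br)cc3)nn2)C(OCc2ccccc2)=C1OCc1ccccc1` — in a functional assay on SW-620 cells (Homo sapiens) for antiproliferative activity, read by MTT assay, with a stated time of 72 h (on this read-out lower numbers stand for stronger inhibition and higher numbers for weaker inhibition), compound 1 gives > 100000 nM, which is a limit of the assay rather than a number.
Compound 2 `CCCCCc1ccc(-c2cn(C[C@H](O)[C@H]3OC(=O)C(OCc4ccccc4)=C3OCc3ccccc3)nn2)cc1` — in this assay compound 2 gives 12200 nM.
Compound 3 `COc1ccccc1-c1cn(C/C=C2\OC(=O)C(OCc3ccccc3)=C2OCc2ccccc2)nn1` — in this assay compound 3 gives > 100000 nM, again a limit of the assay and not a number.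

All three share the same core carrying two benzyl ethers and a triazole ring; they differ in the group on the triazole and in the link between triazole and core. Among the compounds with values here, compound 2 is the only one with a true number, since the other two sit at the limit of > 100000 nM in this assay, at which 2 of the 3 values shown sit. Within the data shown here, the single step between measured compounds, a step that the two limits leave unreadable from compound 1 to compound 3, runs between two limits and gives no readable size.

Compound 4 `Cc1ccc(S(=O)(=O)NCc2cn(C[C@H](O)[C@H]3OC(=O)C(OCc4ccccc4)=C3OCc3ccccc3)nn2)cc1` differs from compound 2 by (((4-methylphenyl)sulfonyl)amino)methyl in place of 4-pentylphenyl on an aromatic carbon. No measured step touches this kind of change: the one step shown concerns a different exchange and cannot be read. Among the measured compounds shown here, with compound 2 as the only anchor and two neighbours at the limit, a weakening beyond the scatter seems the more likely outcome, with a fair chance that only a limit is reported. Compound 4 is therefore expected at 35000 nM, in the range 8000 nM to 150000 nM. That estimate amounts to an expected step of a 2.9-fold higher number from compound 2 to compound 4 (0.46 log units; beyond the scatter).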

Compound 4, half-maximal inhibitory concentration: 45800 nM
Compound 4: the middle estimate sits 1.3-fold (0.12 log units) below what was measured, within the range that was stated.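

With the link to the core held the same, putting (((4-methylphenyl)sulfonyl)amino)methyl in place of 4-pentylphenyl on this aromatic carbon of the five-membered aromatic ring with 3 nitrogen gives a 3.8-fold higher number from compound 2 to compound 4 (0.57 log units; beyond the scatter), the first readable size for any change at this position. The incoming group keeps one six-membered aromatic ring of carbon only and brings a hydrogen-bond donor and hydrogen-bond acceptors that the outgoing group lacks, yet this pair shows inhibition weakened rather than lost. Compound 4 joins compound 2 in giving a true number in this assay, while the other values shown are not numbers: the limit of > 100000 nM in this assay, at which 2 of the 4 values shown sit.

The exchange alters the link to the aromatic ring, the sulfonyl group and the amide-like hydrogen all at once, so the compounds shown cannot say which of these parts accounts for the step. Also open, as far as these compounds go, is how a simple amine, a carboxylic acid or a longer chain on this carbon would compare, and whether the incoming group would give a true number with the other link to the core.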